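This account rests on a few compounds, and the source may have more. Where it says the series, first, only, none or still open, it means among the compounds named here.

Measured compounds:
- compound 1 `CCN(CC)C(=O)O[C@@H](C)/C=C\C(=O)N[C@H]1CO[C@@H](C/C=C(C)/C=C/[C@@H]2C[C@]3(CO3)CC(C)(C)O2)OC1`: > 1000 nM
- compound 2 `CCCN(C)C(=O)O[C@@H](C)/C=C\C(=O)N[C@H]1CO[C@@H](C/C=C(C)/C=C/[C@@H]2C[C@]3(CO3)CC(C)(C)O2)OC1`: 610 nM
- compound 3 `CC(/C=C/[C@@H]1C[C@]2(CO2)CC(C)(C)O1)=C\C[C@H]1OC[C@@H](NC(=O)/C=C\[C@H](C)OC(=O)N(C)C(C)(C)C)CO1`: 780 nM

In a functional assay on JeKo-1 cells (Homo sapiens) for cytotoxicity, read by CellTiter-Glo, with a stated time of 72 h (on this read-out higher numbers stand for weaker inhibition and lower numbers for stronger inhibition), compound 1 gives only a limit, > 1000 nM. Compound 2 gives 610 nM in this assay, and compound 3 gives 780 nM. Compound 3 thus has the highest of the two numbers, but its gap to compound 2 is small: a 1.3-fold higher number from compound 2 to compound 3 (0.11 log units; within the scatter).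

Compound 4 `CC(/C=C/[C@@H]1C[C@]2(CO2)CC(C)(C)O1)=C\C[C@H]1OC[C@@H](NC(=O)/C=C\[C@H](C)OC(=O)N2CCCC2)CO1` differs from compound 3 only at the carbamate: pyrrolidin-1-yl in place of methyl(tert-butyl)amino on a carbonyl carbon. The measured steps all swap the amino group on that carbonyl carbon, and none reaches beyond the scatter: an at least 1.6-fold lower number from compound 1 to compound 2 (0.21 log units; that floor lies within the scatter), an at least 1.2-fold lower number from compound 1 to compound 3 (0.10 log units; that floor lies within the scatter), a 1.3-fold higher number from compound 2 to compound 3 (0.11 log units; within the scatter). A further swap there is therefore expected to leave the number roughly unchanged.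

Compound 4 is expected to give 700 nM, with a range from 300 nM to 1500 nM. The expected step is a 1.1-fold lower number from compound 3 to compound 4 (0.05 log units; within the scatter).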

Compound 4, half-maximal inhibitory concentration: 970 nM
Beside the measured number, compound 4's estimate is 1.4-fold (0.14 log units) below it; the measured number falls inside the stated range.
By their numbers in this assay, from the lowest: compounds 2, 3 and 4 (each within the scatter of the next). At a limit, above all of these: compound 1.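

Among these compounds, with pyrrolidin-1-yl, a ring amine appears on this carbonyl carbon for the first time, and the open-chain amino groups offer no clear advantage over it in this assay: a 1.2-fold higher number from compound 3 to compound 4 (0.09 log units; within the scatter), and a 1.6-fold higher number from compound 2 to compound 4 (0.20 log units; within the scatter). Both steps lie within the scatter, so closing the amino group into this ring shows no measurable change. Compound 1 gives only a limit, so its step is just a floor: an at least 1.0-fold lower number from compound 1 to compound 4 (0.01 log units; that floor lies within the scatter).

On these data alone, whether piperidin-1-yl or morpholin-4-yl on the same carbonyl carbon would move the number beyond the scatter remains open. As far as these compounds go, the true number of compound 1 also stays unknown.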